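The compounds below may be only part of what the source reports. "The series", "measured", "known", "first", "only" and "open" are said of these compounds alone.

Compound 1 `N[C@@H](COP(=O)(O)OCCCOC(=O)CCc1ccccc1OCc1cccc(Oc2ccccc2)c1)C(=O)O` gives 0.48 in an assay on cells for activation of probable G-protein coupled receptor 34 (Mus musculus), with a stated time of 1 h; on this read-out lower numbers stand for smaller maximal responses and higher numbers for larger maximal responses; among the three measured compounds it stands second highest. Compound 2 `Cc1ccccc1Oc1cccc(COc2ccccc2CCC(=O)OCCCOP(=O)(O)OC[C@H](N)C(=O)O)c1` gives 0.28, reached by a number 0.20 lower from compound 1 to compound 2 (beyond the scatter). Compound 3 `N[C@@H](COP(=O)(O)OCCCOC(=O)CCc1ccccc1OCc1cccc(Oc2ccc(I)cc2)c1)C(=O)O` gives 0.82, reached by a number 0.34 higher from compound 1 to compound 3 (beyond the scatter). Compound 4 `CC(C)(C)c1ccc(Oc2cccc(COc3ccccc3CCC(=O)OCCCOP(=O)(O)OC[C@H](N)C(=O)O)c2)cc1` differs from compound 1 by tert-butyl in place of hydrogen on an aromatic carbon. Among the compounds with values here, the closest precedent is the step to compound 3, in which a single substituent replaces hydrogen on an aromatic carbon and the maximal response rises by a large amount, whereas the step to compound 2 shows that a methyl on an aromatic carbon lowers it. Weighing the larger step more, compound 4 is expected to lie above compound 1 by a number 0.22 higher from compound 1 to compound 4 (beyond the scatter), giving an estimated 0.7, with a range from 0.48 to 0.92.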

Compound 4, intrinsic activity: the largest response reached, as a fraction of the reference agonist's: 0.079
Beside the measured number, compound 4's estimate is 0.62 above it; the whole stated range lies above it.
By their numbers in this assay, from the lowest: compound 4; then compound 2; then compound 1; then compound 3.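

In this assay, tert-butyl para to a large group gives a number 0.40 lower from compound 1 to compound 4 (beyond the scatter), so filling this place does not raise the maximal response in general, and iodo and tert-butyl pull in opposite directions. Exchanging iodo for tert-butyl gives a number 0.74 lower from compound 3 to compound 4 (beyond the scatter), while 4-(tert-butyl)phenyl in place of 2-methylphenyl gives a number 0.20 lower from compound 2 to compound 4 (beyond the scatter). Nothing offered here accounts for these differences. From the compounds shown here alone, whether chloro, methoxy or an amine at this same place would follow iodo or tert-butyl remains open.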